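The source may report more compounds than this note shows. Statements on the series, on what has been measured and on what is new or still open speak of the compounds shown alone.

In an ADME assay on HEK293 cells (Homo sapiens) for cytotoxicity, read by MTT assay, with a stated time of 3 days (on this read-out lower numbers stand for stronger inhibition and higher numbers for weaker inhibition), three compounds have been measured so far. Compound 1 (`Nc1ccccc1-c1cccc(O)c1`) gives 10.5 ug/mL, compound 2 (`COc1ccc(-c2ccccc2)cc1`) gives 17 ug/mL and compound 3 (`COc1ccc(-c2cccc(O)c2)cc1`) gives 14.6 ug/mL. Compound 2 thus stands level with the other two, since its value lies within the scatter of both. The next compound, compound 4 (`COc1ccc(-c2ccccc2)c(OC)c1`), differs from compound 2 in one place: methoxy in place of hydrogen on an aromatic carbon. In words, this is methoxy in place of hydrogen on an aromatic carbon, ortho to a group of 6 heavy atoms and meta to a methoxy group.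

Going by the values given here, only one measured step bears on this change, and only indirectly. That step, a 1.2-fold lower number from compound 2 to compound 3 (0.07 log units; within the scatter), also replaces hydrogen on an aromatic carbon, but with hydroxy rather than methoxy, and it stays within the scatter. Among the compounds with values here, no measured pair shows the addition of a methoxy group, so the evidence is thin. Even so, nothing in these compounds points to a step beyond the scatter in this assay, and no direction is favoured. The expected change is small, an estimated 1.1-fold lower number from compound 2 to compound 4 (0.05 log units; within the scatter). For compound 4 the estimated value is 15 ug/mL, with an expected range from 7 ug/mL to 32 ug/mL.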

Compound 4, half-maximal inhibitory concentration: 27 ug/mL
Estimate against measurement, compound 4: 1.8-fold (0.26 log units) below, within the range that was stated.
By their numbers in this assay, from the lowest: compounds 1, 3, 2 and 4 (each within the scatter of the next, the first and the last beyond it).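

The first measured addition of a methoxy group to the shared core, ortho to a group of 6 heavy atoms and meta to a methoxy group, gives a 1.6-fold higher number from compound 2 to compound 4 (0.20 log units; within the scatter) in this assay. Going by these compounds alone, this position therefore takes a methoxy group, with its 2 heavy atoms and 1 hydrogen-bond acceptor, without a shift beyond the scatter, which the earlier compounds could not show, since their only single-place step, a 1.2-fold lower number from compound 2 to compound 3 (0.07 log units; within the scatter), puts a hydroxy group on an aromatic carbon instead. Nothing available here gives a measured property that would account for the number of compound 4.

From the compounds shown here alone, what remains open is whether any group at this same position can move the number beyond the scatter, for instance an amine, a carboxylic acid or a longer chain such as butoxy. Also open, going by these compounds, is whether a hydroxy group here would behave as the methoxy group does, and with only these two small steps in hand, no trend can be drawn for this position.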